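The source may report more compounds than this note shows. Statements on the series, on what has been measured and on what is new or still open speak of the compounds shown alone.

Compound 1 `CN(Cc1cccs1)C1CCN(CCCc2c[nH]c3ccc(-n4cnnc4)cc23)CC1`: 81%
Compound 2 `c1ccc2c(c1)CCC2NC1CCN(CCCc2c[nH]c3ccc(-n4cnnc4)cc23)CC1`: 68%
Compound 3 `C[C@@H](NC1CCN(CCCc2c[nH]c3ccc(-n4cnnc4)cc23)CC1)c1ccccc1`: 90%

Of the compounds shown here, three on a shared core have been tested in a functional assay on CHO cells for activation of 5-hydroxytryptamine receptor 1D (Homo sapiens), read by GTPgammaS binding; on this read-out higher numbers stand for larger maximal responses and lower numbers for smaller maximal responses. Compound 3 stands highest of the three numbers; compound 1 is nearest, a number 9 percentage points higher from compound 1 to compound 3 (within the scatter), and compound 2 is furthest, a number 22 percentage points higher from compound 2 to compound 3 (beyond the scatter). Between compound 1 and compound 2 the difference is a number 13 percentage points lower from compound 1 to compound 2 (beyond the scatter).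

Compound 4 `CN(Cc1ccsc1)C1CCN(CCCc2c[nH]c3ccc(-n4cnnc4)cc23)CC1` has not yet been measured. It differs from compound 3 in one place: methyl((thiophen-3-yl)methyl)amino in place of (1-phenylethyl)amino on a saturated ring carbon. Of the measured steps, the one that bears most directly on this change is the step between compound 1 and compound 3, since compound 1 carries methyl((thiophen-2-yl)methyl)amino on the same saturated ring carbon and compound 4 carries methyl((thiophen-3-yl)methyl)amino there; that step was a number 9 percentage points higher from compound 1 to compound 3 (within the scatter), which is within the scatter. The change from compound 3 to compound 4 runs the other way, from (1-phenylethyl)amino to a methyl-substituted amino bearing a thiophene, so a small downward move or none beyond the scatter is expected. Compound 4 is therefore expected to give about 82%, with a plausible range from 68% to 95%, which is expected to mean a number 8 percentage points lower from compound 3 to compound 4 (within the scatter).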

Compound 4, largest response reached (reported as efficacy), in percent of the reference or control that the assay uses: 93%
The estimate for compound 4 lay 11 percentage points below the measured number, within the range that was stated.
By their numbers in this assay, from the lowest: compound 2; then compounds 1, 3 and 4 (each within the scatter of the next, the first and the last beyond it).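

In this assay, thiophen-3-yl in place of thiophen-2-yl gives a number 12 percentage points higher from compound 1 to compound 4 (beyond the scatter), which shows that on this saturated ring carbon, the point at which the thiophene is attached can alone move the maximal response beyond the scatter. Methyl((thiophen-3-yl)methyl)amino in place of (1-phenylethyl)amino gives a number 3 percentage points higher from compound 3 to compound 4 (within the scatter), so a group with a five-membered aromatic ring and 0 hydrogen-bond donors stands level with one with a six-membered aromatic ring and 1 hydrogen-bond donor, while in place of (2,3-dihydro-1H-inden-1-yl)amino it gives a number 25 percentage points higher from compound 2 to compound 4 (beyond the scatter), leaving compound 2 the lowest of the four. Nothing available explains any of these differences.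

As far as these compounds go, both thiophene compounds carry a methyl on the amine nitrogen, so it remains open whether the difference between thiophen-2-yl and thiophen-3-yl would persist in the secondary amines ((thiophen-2-yl)methyl)amino and ((thiophen-3-yl)methyl)amino. From the compounds shown here alone, it is also open whether furan-3-yl or pyridin-3-yl in place of thiophen-3-yl would keep the response of compound 4 in this assay.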